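This account rests on a few compounds, and the source may have more. Where it says the series, first, only, none or still open, it means among the compounds named here.

Working notes on the series. Compound 1 `Cc1nn(C)c2c1C(c1ccccc1)C(C#N)=C(N)O2` gives 9100 nM in a functional assay on NCI-H2122 cells (Homo sapiens) for inhibition, read by microscopy, with a stated time of 10 days (on this read-out higher numbers stand for weaker inhibition and lower numbers for stronger inhibition), the higher of the two numbers in hand. Among the measured compounds shown here, compound 3 `COc1ccc(C2C(C#N)=C(N)Oc3c2c(-c2ccccc2)nn3-c2ccccc2)cc1` gives 3100 nM in this assay, a lower number, but the two differ in more than one place and no single step joins them. Compound 2 `Cn1nc(-c2ccccc2)c2c1OC(N)=C(C#N)C2c1ccccc1` is reported only as a limit of this assay, > 10000 nM. For the measured compounds named here, the one measured step, phenyl in place of methyl on an aromatic carbon, runs an at least 1.0-fold higher number from compound 1 to compound 2 (0.04 log units; that floor lies within the scatter); it rests on (the limit of > 10000 nM in this assay, at which 1 of the 3 values shown sits), so its true size is open.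

Compound 4 `Cc1nn(C)c2c1C(c1ccc(C(F)(F)F)cc1)C(C#N)=C(N)O2` carries the change (trifluoromethyl in place of hydrogen on an aromatic carbon), with the group entering para to a large group. Going by the values given here, none of the measured steps touches this position, and the phenyl-for-methyl step gives no guide to a trifluoromethyl on the pendant ring. The expectation for this assay is therefore no step beyond the scatter, a 1.2-fold lower number from compound 1 to compound 4 (0.08 log units; within the scatter). Compound 4 is estimated at 7500 nM, within 2500 nM to 20000 nM.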

Compound 4, half-maximal inhibitory concentration: 2200 nM
Estimate against measurement, compound 4: 3.4-fold (0.53 log units) above; the measured number lies below the stated range.
By their numbers in this assay, from the lowest: compounds 4 and 3 (each within the scatter of the next); then compound 1. At a limit, above all of these: compound 2.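

Among the compounds shown here, the ring of carbon only that carries the new group had seen no single change before, and it responds: trifluoromethyl in place of hydrogen gives a 4.1-fold lower number from compound 1 to compound 4 (0.62 log units; beyond the scatter) in this assay. For the compounds shown here, this is the first single change that reads clearly beyond the scatter, so the place para to a large group accepts a trifluoromethyl, and the number goes down rather than up. Nothing measured in the compounds shown bears on the cause of this step.

One group at one place does not separate the trifluoromethyl itself from any other substituent there; an amine, a carboxylic acid or a longer chain at the same place would test that. Also open, on these data alone, is whether the step carries over to the core of compound 2, which is known only as a limit of the assay.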